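From hydroxymethyl to carboxymethyl on the aromatic nitrogen

This account rests on a few compounds, and the source may have more. Where it says the series, first, only, none or still open, it means among the compounds named here.

In a functional assay on NCI-H460 cells (Homo sapiens) for inhibition, with a stated time of 72 h (on this read-out lower numbers stand for stronger inhibition and higher numbers for weaker inhibition), compound 1 `COc1cc(C(=O)c2ccc3[nH]ccc3c2)cc(OC)c1OC` gives 112 nM while compound 2 `CCn1ccc2cc(C(=O)c3cc(OC)c(OC)c(OC)c3)ccc21` gives 38 nM and compound 3 `COc1cc(C(=O)c2ccc3c(ccn3CO)c2)cc(OC)c1OC` gives 39 nM as well. Compound 3 thus stands level with compound 2 and clearly under compound 1. Compound 4 `COc1cc(C(=O)c2ccc3c(ccn3CC(=O)O)c2)cc(OC)c1OC` differs from it by carboxy in place of hydroxy on a saturated chain carbon bound to an aromatic nitrogen. Among the compounds with values here, three measured steps bear on this: the modest 2.9-fold lower number from compound 1 to compound 2 (0.47 log units; beyond the scatter) and a 2.9-fold lower number from compound 1 to compound 3 (0.46 log units; beyond the scatter) when the hydrogen on the aromatic nitrogen is replaced, and a 1.0-fold higher number from compound 2 to compound 3 (0.01 log units; within the scatter) within the scatter. None introduces carboxy, so the direction remains uncertain. The step expected in this assay is a 3.8-fold higher number from compound 3 to compound 4 (0.59 log units; beyond the scatter) which would mean weaker inhibition. Compound 4 is estimated at 150 nM within an expected range from 40 nM to 600 nM overall.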

Compound 4, half-maximal inhibitory concentration: 530 nM
Beside the measured number, compound 4's estimate is 3.5-fold (0.55 log units) below it, and the stated range covers the measured number.
By their numbers in this assay, from the lowest: compounds 2 and 3 (each within the scatter of the next); then compound 1; then compound 4.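

In this assay the aromatic nitrogen no longer looks like a place where any substituent helps: ethyl and hydroxymethyl stood level, but carboxymethyl gives a 14-fold higher number from compound 3 to compound 4 (1.13 log units; beyond the scatter) and likewise a 14-fold higher number from compound 2 to compound 4 (1.14 log units; beyond the scatter). Replacing the hydrogen on that nitrogen can also cost inhibition, as carboxymethyl gives a 4.7-fold higher number from compound 1 to compound 4 (0.68 log units; beyond the scatter) and so reverses the gain seen with the other two groups. Nothing available here accounts for this loss. The compounds shown leave open whether a methyl ester, a primary amide or an aminoethyl group on that nitrogen would stay level with ethyl and hydroxymethyl.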